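The source may report more compounds than this note shows. Statements on the series, on what has been measured and on what is new or still open speak of the compounds shown alone.

Compound 1 `CC(C)[C@@H]1CC[C@@H](C)C[C@@]12N(C)C(=O)[C@@H]1[C@H]3C(=O)NC(=O)[C@H]3ON12`, compound 2 `CC(C)[C@@H]1CC[C@@H](C)C[C@@]12N(C)C(=O)[C@@H]1[C@H]3C(=O)N(C)C(=O)[C@H]3ON12` and compound 3 `CC(C)[C@@H]1CC[C@@H](C)C[C@@]12N(C)C(=O)[C@@H]1[C@H]3C(=O)N(c4ccccc4)C(=O)[C@H]3ON12` share one core and differ only at an amide-type ring nitrogen. In a functional assay, read by spectrophotometry, with a stated time of 2 h (a lower number here means a stronger inhibitor, a higher number a weaker inhibitor), compound 1 gives 1500 ug/mL, compound 2 gives 1400 ug/mL and compound 3 gives 2250 ug/mL. The three steps, a 1.1-fold lower number from compound 1 to compound 2 (0.03 log units; within the scatter), a 1.5-fold higher number from compound 1 to compound 3 (0.18 log units; within the scatter) and a 1.6-fold higher number from compound 2 to compound 3 (0.21 log units; within the scatter), all lie within the scatter, so on these numbers compound 3 is not separated from the other two. Compound 4 `CC(C)[C@@H]1CC[C@@H](C)C[C@@]12N(C)C(=O)[C@@H]1[C@H]3C(=O)N(c4ccc(Cl)cc4)C(=O)[C@H]3ON12` carries chloro in place of hydrogen on an aromatic carbon, phenyl to 4-chlorophenyl. For the measured compounds named here, no measured step alters a substituent on the phenyl itself; the steps that bear on it are those introducing the phenyl, a 1.5-fold higher number from compound 1 to compound 3 (0.18 log units; within the scatter) and a 1.6-fold higher number from compound 2 to compound 3 (0.21 log units; within the scatter), both within the scatter, so no step beyond the scatter is expected in this assay. Compound 4 is therefore expected to give 2200 ug/mL, between 1200 ug/mL and 4000 ug/mL, an expected step of a 1.0-fold lower number from compound 3 to compound 4 (0.01 log units; within the scatter).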

Compound 4, half-maximal inhibitory concentration: 2000 ug/mL
For compound 4 the middle estimate is 1.1-fold (0.04 log units) above the measured one; the measured number falls inside the stated range.
By their numbers in this assay, from the lowest: compounds 2, 1, 4 and 3 (each within the scatter of the next).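

In this assay, for the compounds shown here, the first change on the phenyl itself, chloro on an aromatic carbon para to a large group, gives (a 1.1-fold lower number from compound 3 to compound 4 (0.05 log units; within the scatter)), so this position accepts chloro without a step beyond the scatter. On the amide-type ring nitrogen, 4-chlorophenyl also stays within the scatter of methyl (a 1.4-fold higher number from compound 2 to compound 4 (0.15 log units; within the scatter)) and of hydrogen (a 1.3-fold higher number from compound 1 to compound 4 (0.12 log units; within the scatter)). No supporting data bear on this result.

As far as these compounds go, whether an amine or a carboxylic acid on the phenyl would give a step beyond the scatter remains open. The same question stands for a longer chain on the amide-type ring nitrogen.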